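Shortening the hydroxyalkyl chain on the core of compound 1

The compounds below may be only part of what the source reports. "The series", "measured", "known", "first", "only" and "open" are said of these compounds alone.

Compound 1 `CCCC(O)Cn1ncc(C(=O)OCC)c1NC(=O)NCc1ccccc1` gives 0.0032 nM in a functional assay on cells (Neutrophil, Homo sapiens) for inhibition, with a stated time of 10 min; a lower number here means a stronger inhibitor, a higher number a weaker inhibitor. Among the three measured compounds it stands second highest: compound 3 `CCOC(=O)c1cnn(CC(O)CC)c1NC(=O)Nc1ccccc1F` gives 0.0016 nM, a gap that lies within the scatter, while compound 2 `CCCC(O)Cn1ncc(C(=O)OCC)c1NC(=O)NC(C)C` gives 1 nM. For the measured compounds named here, the one single-point step in the set, a 310-fold higher number from compound 1 to compound 2 (2.49 log units; beyond the scatter), concerns the group on the urea nitrogen and is large.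

Compound 4 `CCOC(=O)c1cnn(CC(C)O)c1NC(=O)NCc1ccccc1` differs from compound 1 elsewhere: hydrogen in place of ethyl on a saturated chain carbon, two bonds along the chain from an oxygen on a saturated carbon. Going by the values given here, no measured step touches this part of the molecule; compound 3 differs from compound 1 at both the chain and the urea group at once, so its value cannot be read as a chain effect on its own. Among the compounds with values here, the change removes no donor or acceptor and no ring, and the urea group that drove the only large step is kept unchanged.

With nothing in the data pointing to a shift, the expected step of a 1.6-fold higher number from compound 1 to compound 4 (0.19 log units; within the scatter) is none beyond the scatter, with a wide range to allow for the unknown. Compound 4 is therefore estimated at 0.005 nM in this assay, between 0.001 nM and 0.03 nM.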

Compound 4, half-maximal inhibitory concentration: 0.00054 nM
Compound 4: the middle estimate sits 9.3-fold (0.97 log units) above what was measured; the measured number lies below the stated range.
By their numbers in this assay, from the lowest: compound 4; then compounds 3 and 1 (each within the scatter of the next); then compound 2.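

Shortening 2-hydroxypentyl to 2-hydroxypropyl while keeping the benzyl urea group gives a 5.9-fold lower number from compound 1 to compound 4 (0.77 log units; beyond the scatter) in this assay, the first single-place reading on this chain. The position therefore affects the number beyond the scatter, and the ethyl removed here is not needed for the low values of this series, since the shorter chain gives the lower number. This modest step still stands well short of the large one at the urea group, a 310-fold higher number from compound 1 to compound 2 (2.49 log units; beyond the scatter), and no measurement at hand accounts for the direction of the chain effect.

Steps involving compound 3 cannot be read as chain effects, since it differs from the others at both the chain and the urea group, so the chain is described by only two single-place end points and its trend remains unknown. Open questions are whether a still shorter 2-hydroxyethyl chain, an amine in place of the hydroxyl, or a longer chain would continue this direction, and whether the isopropyl penalty seen on the longer chain also holds with 2-hydroxypropyl.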